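Swapping the aminopyrazine for a methoxyphenyl on the core

The source may hold more compounds than are shown below. What is called first, only, known or untested is meant among the compounds shown, and "the series" means these compounds.

Compound 1 `Cc1nc2c3ccccc3ccc2c2nc3c(ccc4ccccc43)c(-c3ccccc3)c12` was tested in a functional assay on HeLa cells (Homo sapiens) for cytotoxicity, read by MTT assay, with a stated time of 48 h; on this read-out higher numbers stand for weaker inhibition and lower numbers for stronger inhibition. In that test compound 1 sits at > 80000 nM, which is a limit of the assay and not a number. Compound 2 `Cc1nc2c3ccccc3ccc2c2nc3c(ccc4ccccc43)c(-c3nccnc3N)c12` gives 1210 nM in this assay, the only number shown. The step of an at least 66-fold lower number from compound 1 to compound 2 (1.82 log units; beyond the scatter) was large, with the limit of > 80000 nM in this assay, at which 1 of the 2 values shown sits, marking where compound 1 stands. Compound 3 `COc1ccc(-c2c3ccc4ccccc4c3nc3c2c(C)nc2c4ccccc4ccc32)cc1` differs from compound 2 by 4-methoxyphenyl in place of 3-aminopyrazin-2-yl on an aromatic carbon. Because the step of an at least 66-fold lower number from compound 1 to compound 2 (1.82 log units; beyond the scatter) rewarded the 3-aminopyrazin-2-yl and the entering group is again a ring of carbon only, a large rise in the number is expected. Compound 3 is estimated at 40000 nM, between 8000 nM and 200000 nM. The expected step is a 33-fold higher number from compound 2 to compound 3 (1.52 log units; beyond the scatter).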

Compound 3, half-maximal inhibitory concentration: 45900 nM
Beside the measured number, compound 3's estimate is 1.1-fold (0.06 log units) below it; measured number inside the range.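

The change back to a ring of carbon only does not keep the gain at this position, opposite the ring nitrogen: the 4-methoxyphenyl gives up most of what the 3-aminopyrazin-2-yl won (a 38-fold higher number from compound 2 to compound 3 (1.58 log units; beyond the scatter)). Methoxy on the phenyl ring gives no gain that can be claimed (an at least 1.7-fold lower number from compound 1 to compound 3 (0.24 log units; that floor lies within the scatter)). Compound 1 stands at a limit of the assay, not a number: the limit of > 80000 nM in this assay, at which 1 of the 3 values shown sits.

Still open, going by these compounds, is whether the gain comes from the ring nitrogens or from the amine. A plain pyrazin-2-yl and a 2-aminophenyl would separate the two.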